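The source may report more compounds than this note shows. Statements on the series, on what has been measured and on what is new or still open speak of the compounds shown alone.

Compound 1 `O=C([C@@H]1C[C@H](N2CCN(c3ccc(Br)cc3)CC2)CN1)N1CCSC1` stands second highest of the three numbers in an assay on a cell-free system (plasma) for inhibition of Dipeptidyl peptidase 4 (Rattus norvegicus), read by fluorescence (on this read-out lower numbers stand for stronger inhibition and higher numbers for weaker inhibition), giving 9 nM. Compound 2 `COc1ccc(N2CCN([C@@H]3CN[C@H](C(=O)N4CCSC4)C3)CC2)cc1` gives 16.9 nM, and compound 3 `O=C([C@@H]1C[C@H](N2CCCN(c3ccc([N+](=O)[O-])cc3)CC2)CN1)N1CCSC1` gives 2.9 nM. Going by the values given here, the one step that bears on the present question, a 1.9-fold higher number from compound 1 to compound 2 (0.27 log units; within the scatter), exchanged the substituent on the aromatic ring and stayed within the scatter. Among the compounds with values here, compound 3 differs from compound 1 in more than one place, so its value shows only that lower numbers occur. Compound 4 `N#Cc1ccnc(N2CCN([C@@H]3CN[C@H](C(=O)N4CCSC4)C3)CC2)c1` differs from compound 1 by 4-cyanopyridin-2-yl in place of 4-bromophenyl on an amine nitrogen in a ring. Within the data shown here, this is a broader change than methoxy in place of bromo, yet the only measured guide is that within-scatter step, so the expected step of a 1.2-fold higher number from compound 1 to compound 4 (0.09 log units; within the scatter) is none beyond the scatter. Compound 4 is therefore estimated at 11 nM, within 3.5 nM to 35 nM.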

Compound 4, half-maximal inhibitory concentration: 1.9 nM
For compound 4 the middle estimate is 5.8-fold (0.76 log units) above the measured one; measured number outside the range, below it.
By their numbers in this assay, from the lowest: compounds 4 and 3 (each within the scatter of the next); then compounds 1 and 2 (each within the scatter of the next).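

On the amine nitrogen in the ring, this position now gives a step beyond the scatter in this assay: 4-cyanopyridin-2-yl in place of 4-bromophenyl gives a 4.7-fold lower number from compound 1 to compound 4 (0.68 log units; beyond the scatter) and in place of 4-methoxyphenyl gives an 8.9-fold lower number from compound 2 to compound 4 (0.95 log units; beyond the scatter) while the exchange of bromo and methoxy stayed within the scatter. The position therefore responds to the choice of aromatic ring. Nothing measured here accounts for these steps.

The change brings in the ring nitrogen and the nitrile together, and the compounds shown do not separate the two. A plain pyridin-2-yl or a 4-cyanophenyl group on this nitrogen would tell them apart.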